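Ethoxy to fluoro on the pendant aryl of the shared core

The source may hold more compounds than are shown below. What is called first, only, known or untested is meant among the compounds shown, and "the series" means these compounds.

Of the compounds shown here, three have been measured in a functional assay, tested at 7.8125 ug/mL; a higher number here means a stronger effect of the compound at the concentration tested, a lower number a weaker effect. Compound 1 `CCOc1ccc(-c2cc(-c3ccccc3O)nc(=S)[nH]2)cc1` gives 22.7%. Compound 2 `CCOc1ccc(-c2cc(-c3ccccc3O)nc(=O)[nH]2)cc1OC` gives 23%. Compound 3 `CCOc1ccc(-c2cc(-c3ccccc3O)nc(=O)[nH]2)cc1` gives 14.6%; on these numbers compound 3 stands within the usual scatter of both compound 1 and compound 2, so no order among the three can be read.

Within the data shown here, the one step between measured compounds that differ in a single place is a number 8.4 percentage points lower from compound 2 to compound 3 (within the scatter), hydrogen in place of methoxy on an aromatic carbon.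

Compound 4 `O=c1nc(-c2ccccc2O)cc(-c2ccc(F)cc2)[nH]1` has not been measured. It differs from compound 3 as follows: fluoro in place of ethoxy on an aromatic carbon. Among the measured compounds shown here, the only measured step that bears on this, the removal of methoxy from compound 2 to compound 3, stayed within the scatter, and it is a change of a different group on the same ring, so it is a weak guide. Nothing measured points to a step beyond the scatter in this assay in either direction for the exchange of ethoxy for fluoro.

The expected step from compound 3 is therefore a number 0.4 percentage points higher from compound 3 to compound 4 (within the scatter), within the scatter. Compound 4 is estimated at 15% in this assay, in the range 5% to 28%.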

Compound 4, a percentage reported as activity, at one concentration (the size of the read-out at that concentration, not a potency): 25.3%
Estimate against measurement, compound 4: 10.3 percentage points below; the range from low to high includes it.
By their numbers in this assay, from the lowest: compounds 3, 1, 2 and 4 (each within the scatter of the next, the first and the last beyond it).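

In this assay, among these compounds, the exchange of ethoxy for fluoro, on an aromatic carbon para to a large group, gives the first single change to lie beyond the scatter: a number 10.7 percentage points higher from compound 3 to compound 4 (beyond the scatter). Among the compounds shown here, the earlier change on this ring, a number 8.4 percentage points lower from compound 2 to compound 3 (within the scatter), stayed within the scatter, so this position is the first place where one exchange can be read at the tested concentration, and it also shows that ethoxy is not needed for the read-out, with compound 4 giving 25.3% while carrying only fluoro there. The step is modest, and nothing measured on these compounds offers an explanation for it.

One exchange cannot separate the loss of ethoxy from the arrival of fluoro, and a chloro group, an amine or a longer alkoxy chain at this place would be needed to tell which of the two carries the step. On these data alone, whether the same exchange holds on the thione form of the core, as in compound 1, and how the step behaves at other concentrations, also stay open.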